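Shrinking the Amide on the Shared Core

The compounds below may be only part of what the source reports. "The series", "measured", "known", "first", "only" and "open" are said of these compounds alone.

In a functional assay on MCF7 cells (Homo sapiens) for antiproliferative activity, read by MTT assay, with a stated time of 48 h (a higher number here means a weaker inhibitor, a lower number a stronger inhibitor), compound 3 (`CC(C)=CCC[C@]1(C)/C=C/[C@@H](OC(=O)C=C(C)C)[C@](C)(O)/C=C/C(=O)/C(C(=O)N(C(C)C)C(C)C)=C\C1`) stands highest of the three measured compounds at 17200 nM. Compound 1 (`CC(C)=CCC[C@]1(C)/C=C/[C@@H](OC(=O)C=C(C)C)[C@](C)(O)/C=C/C(=O)/C(CCl)=C\C1`) gives 610 nM, and compound 2 (`CC(C)=CCC[C@]1(C)/C=C/[C@@H](OC(=O)C=C(C)C)[C@](C)(O)/C=C/C(=O)/C(C(=O)N(C)C)=C\C1`) gives 3670 nM. Compound 4 (`CC(C)=CCC[C@]1(C)/C=C/[C@@H](OC(=O)C=C(C)C)[C@](C)(O)/C=C/C(=O)/C(C(=O)N2CCCC2)=C\C1`) carries pyrrolidin-1-yl in place of diisopropylamino on a carbonyl carbon. The closest measured change is a 4.7-fold higher number from compound 2 to compound 3 (0.67 log units; beyond the scatter), a modest step with diisopropylamino replacing dimethylamino. The large 28-fold higher number from compound 1 to compound 3 (1.45 log units; beyond the scatter) and the modest 6.0-fold higher number from compound 1 to compound 2 (0.78 log units; beyond the scatter) replace chloromethyl and bear on it less directly. No amide with a ring has been measured, so a modest step towards a lower number is expected. The estimated change is a 3.8-fold lower number from compound 3 to compound 4 (0.58 log units; beyond the scatter). For compound 4 the estimate is 4500 nM, with an expected range from 1500 nM to 13000 nM.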

Compound 4, half-maximal inhibitory concentration: 17200 nM
For compound 4 the middle estimate is 3.8-fold (0.58 log units) below the measured one; the whole stated range lies below it.
By their numbers in this assay, from the lowest: compound 1; then compound 2; then compounds 3 and 4 (each within the scatter of the next).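

The ring changes nothing here: in this assay there is no change at the digits printed from compound 3 to compound 4 (within the scatter) when pyrrolidin-1-yl replaces diisopropylamino on this carbonyl carbon. Compound 4 also remains apart from the other two, with a 4.7-fold higher number from compound 2 to compound 4 (0.67 log units; beyond the scatter) and a 28-fold higher number from compound 1 to compound 4 (1.45 log units; beyond the scatter) printed for its steps, so dimethylamino gives the lowest number among the three amides. Nothing available explains this result.

On these data alone, whether an azetidin-1-yl or morpholin-4-yl amide, or a secondary amide keeping the amide hydrogen, would come closer to compound 2 or compound 1 remains open.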